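The compounds below may be only part of what the source reports. "The series", "measured", "known", "first", "only" and "open" are said of these compounds alone.

Compound 1 `O=C1N=C(N2N=C(c3ccccc3)CC2c2ccccc2O)S/C1=C1/C(=O)Nc2ccccc21` is the parent of the first pair. In a functional assay on cells (Leukemia cell, Homo sapiens) for cytotoxicity, read by sulforhodamine B assay, with a stated time of 48 h (on this read-out lower numbers stand for stronger inhibition of growth and higher numbers for weaker inhibition of growth), compound 1 gives 48800 nM. Compound 2 `O=C1N=C(N2N=C(c3ccccc3)CC2c2ccccc2O)S/C1=C1/C(=O)Nc2ccc(Br)cc21` carries one change, (bromo in place of hydrogen on an aromatic carbon), and in this assay compound 2 gives 1050 nM, so that a 46-fold lower number from compound 1 to compound 2 (1.67 log units; beyond the scatter). Compound 3 `COc1ccc(C2=NN(C3=NC(=O)/C(=C4\C(=O)Nc5ccccc54)S3)C(c3ccc(Cl)cc3)C2)cc1` is built on a different core; the difference between the two cores is not broken down here. In this assay compound 3 gives 90900 nM, which lies within the scatter of the value of compound 1. Compound 4 `COc1ccc(C2=NN(C3=NC(=O)/C(=C4\C(=O)Nc5ccc(Br)cc54)S3)C(c3ccc(Cl)cc3)C2)cc1` differs from compound 3 by bromo in place of hydrogen on an aromatic carbon, the same change as that from compound 1 to compound 2. Because the earlier step was a 46-fold lower number from compound 1 to compound 2 (1.67 log units; beyond the scatter), the step from compound 3 to compound 4 is expected to be similar, a 23-fold lower number from compound 3 to compound 4 (1.36 log units; beyond the scatter), though a single pair supports it. For compound 4 the estimate in this assay is 4000 nM, between 900 nM and 20000 nM.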

Compound 4, concentration for total growth inhibition: 14000 nM
Compound 4: the middle estimate sits 3.5-fold (0.54 log units) below what was measured; measured number inside the range.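

In this assay bromo in place of hydrogen on an aromatic carbon again lowers the number, giving a 6.5-fold lower number from compound 3 to compound 4 (0.81 log units; beyond the scatter) on the second core, so the direction of the step carries over. Its size does not carry over: the same change on two cores in this assay, a 46-fold lower number (1.67 log units; beyond the scatter) from compound 1 to compound 2 and a 6.5-fold lower number (0.81 log units; beyond the scatter) from compound 3 to compound 4, 7.2-fold (0.85 log units) apart, beyond the scatter of two such steps. These two pairs do not show which difference between the cores goes with that gap, or how the change would behave on any further core.

The compounds shown leave open whether fluoro on the same ring carbon would give a similar step. They also leave open what an amine or a carboxylic acid at that place would do on either core.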